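Shifting the Methyl Group on the Phenyl Ring of Compound 3

The source may hold more compounds than are shown below. What is called first, only, known or untested is meant among the compounds shown, and "the series" means these compounds.

In a functional assay on KBVIN cells (Homo sapiens) for antiproliferative activity, read by sulforhodamine B assay, with a stated time of 3 days (a higher number here means that more compound is needed for the effect, a lower number that less compound is needed), compound 1 `CCC1=C(O)c2c(oc(-c3ccc(CC)cc3)cc2=O)C(CC)(CC)C1=O` gives 0.07 uM, compound 2 `CCC1=C(O)c2c(oc(-c3ccc(C(C)C)cc3)cc2=O)C(CC)(CC)C1=O` gives 1.08 uM, and compound 3 `CCC1=C(O)c2c(oc(-c3cccc(C)c3)cc2=O)C(CC)(CC)C1=O` gives 3.69 uM. Compound 3 therefore has the highest number of the three, meaning that the most compound is needed for the effect.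

Compound 4 `CCC1=C(O)c2c(oc(-c3ccccc3C)cc2=O)C(CC)(CC)C1=O` keeps the shared core but has 2-methylphenyl in place of 3-methylphenyl on an aromatic carbon. Within the data shown here, no measured step shows this exact change. The closest evidence comes from swapping the aromatic group, which gave a large step, a 53-fold higher number from compound 1 to compound 3 (1.72 log units; beyond the scatter), and a modest one, a 3.4-fold higher number from compound 2 to compound 3 (0.53 log units; beyond the scatter). Adding a methyl in place of hydrogen on the chain also gave a large step, a 15-fold higher number from compound 1 to compound 2 (1.19 log units; beyond the scatter). These steps show that small edits here can matter, but they do not fix a direction for this one. A modest rise is tentatively expected, and the expected step is a 2.2-fold higher number from compound 3 to compound 4 (0.34 log units; beyond the scatter). The estimate for compound 4 is 8 uM, with an expected range from 2 uM to 30 uM.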

Compound 4, concentration for half-maximal effect: 2.41 uM
Beside the measured number, compound 4's estimate is 3.3-fold (0.52 log units) above it; the range from low to high includes it.
By their numbers in this assay, from the lowest: compound 1; then compound 2; then compounds 4 and 3 (each within the scatter of the next).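

The 3-methylphenyl and 2-methylphenyl groups cannot be told apart in this assay, with a 1.5-fold lower number from compound 3 to compound 4 (0.19 log units; within the scatter), so on this aromatic carbon next to the ring oxygen, the two methyl placements read alike. The 2-methylphenyl group nevertheless remains well separated from the 4-ethylphenyl group, with a 34-fold higher number from compound 1 to compound 4 (1.54 log units; beyond the scatter), and more modestly from the 4-isopropylphenyl group, with a 2.2-fold higher number from compound 2 to compound 4 (0.35 log units; beyond the scatter). Nothing shown here offers a reason for these numbers.

Open, going by these compounds, is how a 4-methylphenyl group would read on the shared core, which would complete the set of methyl placements. Also open, on these data alone, is whether a 4-propylphenyl group or an amine on the phenyl ring would stay close to the low number of compound 1 or fall with the other compounds.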